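Fluoro on the pyridine ring of a pyrrolidine thiosemicarbazone

The source may hold more compounds than are shown below. What is called first, only, known or untested is meant among the compounds shown, and "the series" means these compounds.

Measured compounds:
compound 1 `N/C(=N\NC(=S)N1CCSCC1)c1ccccn1`, 7800 nM
compound 2 `N/C(=N\NC(=S)N1CCOCC1)c1ccc(F)cn1`, 1700 nM
compound 3 `N/C(=N\NC(=S)N1CCCC1)c1ccccn1`, 6200 nM

In a functional assay on HeLa cells (Homo sapiens) for cytotoxicity, read by MTT assay, with a stated time of 72 h (on this read-out higher numbers stand for weaker inhibition and lower numbers for stronger inhibition), compound 1 gives 7800 nM, compound 2 gives 1700 nM and compound 3 gives 6200 nM. Compound 3 stands second highest of the three numbers; its nearest neighbour is compound 1, and the step of a 1.3-fold lower number from compound 1 to compound 3 (0.10 log units; within the scatter) lies within the scatter, so the two cannot be told apart. Compound 2 is furthest from compound 3, with a lower number beyond the scatter, but it differs from compound 3 in two places, so its value alone does not isolate either change.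

Compound 4 `N/C(=N\NC(=S)N1CCCC1)c1ccc(F)cn1` differs from compound 3 by one change: fluoro in place of hydrogen on an aromatic carbon. Within the data shown here, no measured step isolates this change. Among the measured compounds shown here, the only measured step, a 1.3-fold lower number from compound 1 to compound 3 (0.10 log units; within the scatter), concerns the ring on the thiocarbonyl carbon and was within the scatter, so it says nothing about fluoro. Compound 2, the only fluoro-bearing compound, has the lowest number shown, which is the sole hint available. On that basis a lower number is expected for compound 4, with the step of a 2.6-fold lower number from compound 3 to compound 4 (0.41 log units; beyond the scatter) estimated from compound 2 1700 nM. Compound 4 is therefore estimated at 2400 nM, within 900 nM to 6000 nM.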

Compound 4, half-maximal inhibitory concentration: 1800 nM
The estimate for compound 4 lay 1.3-fold (0.12 log units) above the measured number; the measured number falls inside the stated range.
By their numbers in this assay, from the lowest: compounds 2 and 4 (each within the scatter of the next); then compounds 3 and 1 (each within the scatter of the next).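

In this assay, fluoro in place of hydrogen on an aromatic carbon, two atoms from the ring nitrogen and para to a large group, gives a 3.4-fold lower number from compound 3 to compound 4 (0.54 log units; beyond the scatter). Among these compounds, this is the first step to isolate the change, with the pyrrolidin-1-yl group held constant, and it rests on this single pair. With fluoro present, the exchange of the ring on the thiocarbonyl carbon gives a 1.1-fold higher number from compound 2 to compound 4 (0.02 log units; within the scatter), so in this one pair of fluoro compounds pyrrolidin-1-yl and morpholin-4-yl cannot be told apart; no evidence is available on why the fluoro step arises.

The compounds shown leave open whether chloro, methyl or methoxy on this same carbon would give a step like that of fluoro, and whether fluoro on another carbon of the ring would do so. They also leave open whether the fluoro step carries over to the thiomorpholin-4-yl compound, since compound 1 has no fluoro-bearing partner among them.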